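Swapping a chlorine for a hydroxyl on a cytotoxic scaffold

The source may hold more compounds than are shown below. What is called first, only, known or untested is meant among the compounds shown, and "the series" means these compounds.

Of the compounds shown here, three have been tested in a functional assay on SW-620 cells (Homo sapiens) for cytotoxicity, read by MTT assay, with a stated time of 72 h; a lower number here means a stronger inhibitor, a higher number a weaker inhibitor. Compound 1 `COc1cccc(/C=C2\CCC/C(=C\c3cc(Cl)cc(Cl)c3)C2=O)c1OC` gives 5500 nM. Compound 2 `COc1cccc(/C=C2\CCC/C(=C\c3ccc(O)c(Cl)c3)C2=O)c1OC` differs from it in one place, (3-chloro-4-hydroxyphenyl in place of 3,5-dichlorophenyl on a double-bonded chain carbon bound to a double-bonded ring carbon), and gives 16800 nM; this amounts to a 3.1-fold higher number from compound 1 to compound 2 (0.48 log units; beyond the scatter), a weakening of the inhibition. Compound 3 `COc1ccc(/C=C2\CCC/C(=C\c3cc(Cl)cc(Cl)c3)C2=O)cc1OC` gives 2500 nM, the lowest of the three numbers and therefore the strongest inhibitor measured so far, with compound 1 nearest and compound 2 furthest away. Compound 3 and compound 1 are built from the same atoms joined differently; the difference between the two cores is not broken down here.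

Compound 4 `COc1ccc(/C=C2\CCC/C(=C\c3ccc(O)c(Cl)c3)C2=O)cc1OC` has not yet been measured. Among the measured compounds shown here, it differs from compound 3 by 3-chloro-4-hydroxyphenyl in place of 3,5-dichlorophenyl on a double-bonded chain carbon bound to a double-bonded ring carbon, which is the same change, at the same kind of place, as the one that turned compound 1 into compound 2. For the measured compounds named here, only that one earlier example of the change is available, and it came out beyond the usual scatter of repeated runs. On that basis the step from compound 3 to compound 4 is expected to be of similar size and direction, roughly a 3.1-fold higher number from compound 3 to compound 4 (0.49 log units; beyond the scatter), since the earlier step gave a 3.1-fold higher number from compound 1 to compound 2 (0.48 log units; beyond the scatter). Compound 4 is therefore estimated to reach about 7800 nM in this assay, with the plausible range running from 3800 nM to 16000 nM, a weaker inhibitor than compound 3 but, if the earlier pattern holds, still stronger than compound 2.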

Compound 4, half-maximal inhibitory concentration: 7100 nM
The estimate for compound 4 lay 1.1-fold (0.04 log units) above the measured number; the measured number falls inside the stated range.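

Putting 3-chloro-4-hydroxyphenyl in place of 3,5-dichlorophenyl on the core of compound 3 gives a 2.8-fold higher number from compound 3 to compound 4 (0.45 log units; beyond the scatter) in this assay, so the inhibition weakens here as well. Set side by side, the two steps agree in direction and in size: the same change on two cores in this assay, a 3.1-fold higher number (0.48 log units; beyond the scatter) from compound 1 to compound 2 and a 2.8-fold higher number (0.45 log units; beyond the scatter) from compound 3 to compound 4, 1.1-fold (0.03 log units) apart, within the scatter of two such steps. This shows that, on these two cores, the change carried over from one to the other with its effect essentially intact, but two cores are only a small sample, so it does not show that the same step would appear on a further core, and it does not explain why the inhibition weakens or whether the hydroxyl entering or the chlorine leaving matters more.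

The compounds shown leave open how a ring carrying a hydroxyl and no chlorine would behave on either core, which would help to separate the two parts of this swap. They also leave open whether an amine or a carboxylic acid in the place of the hydroxyl would follow the same course, and whether the step would keep its size on cells other than those used here.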